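The source may hold more compounds than are shown below. What is called first, only, known or untested is meant among the compounds shown, and "the series" means these compounds.

Compound 1 `CCCNC(=C\C(=O)/C=C/c1ccc(O)c(OC)c1)/C=C/c1ccc(O)c(OC)c1` was tested in an ADME assay on EA.hy 926 cells (Homo sapiens) for inhibition, read by MTT assay, with a stated time of 72 h (on this read-out lower numbers stand for stronger inhibition and higher numbers for weaker inhibition), where compound 1 gives > 25000 nM, which is a limit of the assay and not a number. Two related compounds carry the same kind of result. Compound 2 `COc1cc(/C=C/C(=O)/C=C(/C=C/c2ccc(OC(C)=O)c(OC)c2)NC2CCCCC2)ccc1OC(C)=O` gives > 25000 nM in this assay, a limit. Compound 3 `COc1cc(/C=C/C(=O)/C=C(/C=C/c2ccc(OC(C)=O)c(OC)c2)NCC(C)C)ccc1OC(C)=O` gives > 25000 nM in this assay, again a limit. The step that the two limits leave unreadable from compound 2 to compound 3 therefore cannot be read, since the limit of > 25000 nM in this assay, at which 3 of the 3 values shown sit, is where all three values sit. Compound 4 `CCCCNC(=C\C(=O)/C=C/c1ccc(O)c(OC)c1)/C=C/c1ccc(O)c(OC)c1` has not yet been measured; it differs from compound 1 by methyl in place of hydrogen on a saturated chain carbon, three bonds along the chain from an amine nitrogen. No measured step bears on this change, and every shown value sits at the limit. Compound 4 is therefore expected to give 30000 nM, between 12000 nM and 80000 nM, most likely again only a limit. The expected step that the limit leaves unreadable from compound 1 to compound 4 is then none beyond the scatter.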

Compound 4, half-maximal inhibitory concentration: > 25000 nM
Compound 4 was reported as a limit (the forecaster's own chance of this, stated with the estimate: 85%); the middle value lies beyond the limit too.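

Compound 1 and compound 4 are both reported only as limits, so the size of the step between them cannot be read: the limit of > 25000 nM in this assay, at which 4 of the 4 values shown sit.

The compounds shown leave open how strongly any of them inhibits, and whether the amine's chain matters at all.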